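From chloro to hydroxy at the assay limit

This account rests on a few compounds, and the source may have more. Where it says the series, first, only, none or still open, it means among the compounds named here.

Compound 1 `Nc1nc(N)c2ncn([C@H]3CCCC[C@H]3CO)c2n1` gives > 200000 nM as a limit
Compound 2 `Nc1nc(Cl)c2ncn([C@H]3CCCC[C@H]3CO)c2n1` gives > 200000 nM as a limit

In an ADME assay on L1210/0 cells (Mus musculus) for cytotoxicity, with a stated time of 48 h (on this read-out higher numbers stand for weaker inhibition and lower numbers for stronger inhibition), compound 2 gives > 200000 nM as a limit and not as a number. Compound 3 `Nc1nc(O)c2ncn([C@H]3CCCC[C@H]3CO)c2n1` differs from it by one change, hydroxy in place of chloro on an aromatic carbon with hydroxy in place of chloro on an aromatic carbon. For the measured compounds named here, the only measured step is a step that the two limits leave unreadable from compound 1 to compound 2 and it has no readable size. The data offer the limit of > 200000 nM in this assay, at which 2 of the 2 values shown sit, and no number to scale from. No step beyond the scatter is therefore expected in this assay and the expected step is a number no higher from compound 2 to compound 3 (the limit leaves the size open) here. Compound 3 is estimated at 200000 nM with an expected range from 100000 nM to 400000 nM overall.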

Compound 3, half-maximal inhibitory concentration: > 200000 nM
Compound 3: a limit, no number; the forecaster's own chance of this, stated with the estimate: 85%; the middle value sits exactly at the limit.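

In this assay, compound 1, compound 2 and compound 3 each give only a limit, so no step between them can be read: the limit of > 200000 nM in this assay, at which 3 of the 3 values shown sit.

From the compounds shown here alone, whether amino, chloro and hydroxy on this aromatic carbon differ at all in this assay stays open.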